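Ring Fusion at the Amine Substituent of Compound 2

A few compounds are considered here, and "the series" means these few. Any claim that something is new, unique, unknown or untested is made for them only; others in the source may bear on it.

In a functional assay on CCRF-CEM cells for antagonist activity at C-X-C chemokine receptor type 4 (Homo sapiens), read by calcium flux, with stated times of 25 min and 90 s (on this read-out lower numbers stand for stronger inhibition and higher numbers for weaker inhibition), compound 1 `CN(C)[C@H]1CCN(c2cccc3c2C[C@H](CN(C)[C@H]2CCCc4cccnc42)NC3)C1` gives 10.9 nM, compound 2 `CN(C)[C@@H]1CCN(c2cccc3c2C[C@H](CN(C)[C@H]2CCCc4cccnc42)NC3)C1` gives 10.4 nM and compound 3 `CN1CCN(Nc2cccc3c2C[C@@H](CN(C)[C@H]2CCCc4cccnc42)NC3)CC1` gives 47.4 nM. Compound 2 has the lowest of the three numbers, yet its gap to compound 1 lies within the scatter, and only its gap to compound 3 lies beyond it. The step of a 1.0-fold lower number from compound 1 to compound 2 (0.02 log units; within the scatter) rests on (the fact that compounds 1 and 2 differ only in the configuration as drawn). Compound 4 `CN1C[C@@H]2CN(c3cccc4c3C[C@H](CN(C)[C@H]3CCCc5cccnc53)NC4)C[C@@H]2C1` carries a group of 9 heavy atoms (7 carbon, 2 nitrogen; 2 five-membered non-aromatic rings with 1 hetero atom each) in place of a group of 8 heavy atoms (6 carbon, 2 nitrogen; one five-membered non-aromatic ring with 1 hetero atom), on an aromatic carbon. Within the data shown here, the only measured step concerns a change in configuration, not a change of group, so it offers little guidance here. For compound 4 the expected step is a 1.2-fold higher number from compound 2 to compound 4 (0.06 log units; within the scatter), none beyond the scatter. Compound 4 is therefore estimated to give 12 nM, between 5 nM and 35 nM.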

Compound 4, half-maximal inhibitory concentration: 9.56 nM
Compound 4: middle estimate off by 1.3-fold (0.10 log units), on the high side, and the stated range covers the measured number.
By their numbers in this assay, from the lowest: compounds 4, 2 and 1 (each within the scatter of the next); then compound 3.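

In this assay, putting the fused two-ring group in place of the 3-(dimethylamino)pyrrolidin-1-yl group gives a 1.1-fold lower number from compound 2 to compound 4 (0.04 log units; within the scatter) and a 1.1-fold lower number from compound 1 to compound 4 (0.06 log units; within the scatter). The two steps start from two drawn forms of the same group: the fact that compounds 1 and 2 differ only in the configuration as drawn. So this aromatic carbon carries a second five-membered ring, with its two defined stereocentres, and neither step goes beyond the scatter.

Open, as far as these compounds go, is whether a carboxylic acid or an open-chain amine such as a dimethylaminoethyl chain on this aromatic carbon would give a similar number. Also open, from the compounds shown here alone, is whether the opposite configuration of the fused rings would.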